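Carboxy in Place of Nitro on a Naphthol Biaryl

A few compounds are considered here, and "the series" means these few. Any claim that something is new, unique, unknown or untested is made for them only; others in the source may bear on it.

Measured so far:
compound 1 `OCc1ccc(-c2ccc3c(O)cccc3c2)cc1`: 31%
compound 2 `O=[N+]([O-])c1ccc(-c2ccc3c(O)cccc3c2)cc1`: 13%

Among the compounds with values here, in an assay for binding affinity to 17-beta-hydroxysteroid dehydrogenase type 2 (Homo sapiens), with a stated time of 20 min, tested at 1 uM (a lower number here means less inhibition, a higher number more inhibition at the concentration tested (going by the name of the read-out)), compound 2 gives the lowest of the two numbers; the nearest is compound 1, whose value stands higher, and the one measured step, a number 18 percentage points lower from compound 1 to compound 2 (beyond the scatter), goes downward. Compound 3 `O=C(O)c1ccc(-c2ccc3c(O)cccc3c2)cc1` is not yet measured. It differs from compound 2 by carboxy in place of nitro on an aromatic carbon. Within the data shown here, no measured step involves a carboxy group, so the only guide is the size of the single step seen. A change of similar modest size, in either direction or none, is expected, so compound 3 is estimated at 20% (range 5% to 40%), a step of a number 7 percentage points higher from compound 2 to compound 3 (within the scatter).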

Compound 3, a percentage reported as inhibition, at one concentration (the size of the read-out at that concentration, not a potency): 16%
Compound 3: the middle estimate sits 4 percentage points above what was measured; the measured number falls inside the stated range.
By their numbers in this assay, from the lowest: compounds 2 and 3 (each within the scatter of the next); then compound 1.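

In this assay the step is a number 3 percentage points higher from compound 2 to compound 3 (within the scatter) so carboxy and nitro cannot be told apart at this place, para to a large group. Carboxy in place of hydroxymethyl gives a number 15 percentage points lower from compound 1 to compound 3 (beyond the scatter) so hydroxymethyl now stands above two different groups instead of one. Nothing measured here explains why hydroxymethyl gives the higher number.

Going by these compounds, whether an amine or a longer chain ending in a hydroxyl group would match or exceed hydroxymethyl at this place remains open. So does the effect of changes elsewhere on the shared core.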